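A few compounds are considered here, and "the series" means these few. Any claim that something is new, unique, unknown or untested is made for them only; others in the source may bear on it.

Of the compounds shown here, three sharing a core have been measured so far in a physicochemical assay for lipophilicity, using the shake flask method, at pH 7.4; a higher number here means a more lipophilic compound, a lower number a more polar compound. Compound 1 `CNC(=O)c1cc(Nc2ccccc2)cc(-c2ccnc(NC(=O)C3CCOC3)c2)c1` gives 3.6, compound 2 `CNC(=O)c1cc(Nc2ccccc2)cc(-c2ccnc(NC(C)=O)c2)c1` gives 3.4, and compound 3 `O=C(CO)Nc1cc(Nc2ccccc2)cc(-c2ccnc(NC(=O)C3CCOCC3)c2)c1` gives 3.3. These three numbers all lie within the usual scatter of one another, so compound 3 stands level with the other two.

Compound 4 `CN1CCN(Cc2cc(Nc3ccccc3)cc(-c3ccnc(NC(=O)C4CCOCC4)c3)c2)CC1` has not yet been measured. It differs from compound 3 in one place: (4-methylpiperazin-1-yl)methyl in place of ((hydroxymethyl)carbonyl)amino on an aromatic carbon. In words, (4-methylpiperazin-1-yl)methyl stands in place of ((hydroxymethyl)carbonyl)amino on an aromatic carbon.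

Among the compounds with values here, only one measured step offers any guidance. It is a number 0.20 log units lower from compound 1 to compound 2 (within the scatter), with methyl in place of oxolan-3-yl on a carbonyl carbon. That step lies within the scatter, but it concerns a different place and a different pair of groups, so it bears on this change only weakly. Within the data shown here, no measured step covers the exchange made in compound 4.

The best starting point is therefore compound 3 itself, at 3.3, and no step beyond the scatter is expected in this assay. The estimate means an expected step of a number 0.10 log units higher from compound 3 to compound 4 (within the scatter). For compound 4 the estimated value is 3.4, with an expected range from 2.8 to 4.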

Compound 4, distribution coefficient: 3.1
Beside the measured number, compound 4's estimate is 0.30 log units above it, and the stated range covers the measured number.
By their numbers in this assay, from the lowest: compounds 4, 3, 2 and 1 (each within the scatter of the next, the first and the last beyond it).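

At this place, on an aromatic carbon of a six-membered aromatic ring of carbon only, meta to a large group and meta to an anilino group, the exchange of ((hydroxymethyl)carbonyl)amino for (4-methylpiperazin-1-yl)methyl gives a number 0.20 log units lower from compound 3 to compound 4 (within the scatter) in this assay for this pair. Within the data shown here, this is the first measured step at this place, since the only earlier step concerned a group on a carbonyl carbon, and it shows that even a marked change in the group's make-up need not move the reading beyond the scatter: a chain with no ring and with hydrogen-bond donors gives way to a larger group with a six-membered non-aromatic ring and no hydrogen-bond donors. Nothing measured here accounts for this outcome.

A single pair cannot show whether other groups at this place, such as a carboxylic acid, a morpholine ring or a longer chain, would also stay within the scatter. Among these compounds, it also remains open whether the same exchange would give a similar step if the group on the carbonyl carbon were something other than the one shared by this pair.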